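Shortening the Chain of Compound 2

The source may report more compounds than this note shows. Statements on the series, on what has been measured and on what is new or still open speak of the compounds shown alone.

Measured in a functional assay on MCF7 cells (Homo sapiens) for inhibition, read by MTT assay, with a stated time of 72 h; a lower number here means a stronger inhibitor, a higher number a weaker inhibitor:
Compound 1 `CNC(=O)CCCCCCCn1nc(-c2cnc3[nH]ccc3c2)c2c(N)ncnc21`: 7570 nM
Compound 2 `Nc1ncnc2c1c(-c1cnc3[nH]ccc3c1)nn2CCCCCCCCC(=O)NO`: 24700 nM
Not yet measured: compound 3 `Nc1ncnc2c1c(-c1cnc3[nH]ccc3c1)nn2CCCCC(=O)NO`

Of the two measured compounds, compound 2 has the higher number in this assay, at 24700 nM, and is therefore the weaker inhibitor. The change that leads to compound 3 is this: hydroxycarbamoyl in place of 4-(hydroxycarbamoyl)butyl on a saturated chain carbon, four bonds along the chain from an aromatic nitrogen. Among the compounds with values here, the only measured step, a 3.3-fold higher number from compound 1 to compound 2 (0.51 log units; beyond the scatter), is modest and altered the end of the chain, not its length, so it bears on this change only loosely. Within the data shown here, no measured step shortens a chain, which leaves no basis for choosing a direction. No clear change is therefore expected, and the expected step is a 1.1-fold lower number from compound 2 to compound 3 (0.05 log units; within the scatter). For compound 3 the estimated value is 22000 nM, with an expected range of 7000 nM to 70000 nM.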

Compound 3, half-maximal inhibitory concentration: > 150000 nM
Compound 3: only a limit was reported; the forecaster's own chance of this, stated with the estimate: 15%; middle value at least 6.8-fold (0.83 log units) from the limit.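

In this assay compound 3 gives only a limit, not a number: the limit of > 150000 nM in this assay, at which 1 of the 3 values shown sits. Even so, hydroxycarbamoyl in place of 4-(hydroxycarbamoyl)butyl gives an at least 6.0-fold higher number from compound 2 to compound 3 (0.78 log units; beyond the scatter), which shows that, for these compounds, shortening the chain changes the result in a way the earlier change at the chain end did not reveal. The wider step, an at least 19-fold higher number from compound 1 to compound 3 (1.29 log units; beyond the scatter), alters both the length of the chain and the group at its end, so it cannot be assigned to length alone.

The compounds shown leave open whether a chain of intermediate length ending in hydroxycarbamoyl stays close to compound 2 or falls to the limit seen for compound 3. They also leave open how a short chain ending in methylcarbamoyl, a carboxylic acid or an amine would behave, and what a chain longer than that of compound 2 would give.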